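Ester to Hydroxyethyl Amide on a Lipase Series

A few compounds are considered here, and "the series" means these few. Any claim that something is new, unique, unknown or untested is made for them only; others in the source may bear on it.

Measured compounds:
Compound 1, `CCCCCCCCN(C)C(=O)Cn1cc(Cc2cnc(OC)nc2)c(=O)nc1SCc1ccc(F)cc1`: 13%
Compound 2, `CCCCCCCCN(C)C(=O)Cn1cc(Cc2cnc(OCC)nc2)c(=O)nc1SCc1ccc(F)cc1`: 7%
Compound 3, `CCCCCCCCCCCCN(C)C(=O)Cn1cc(Cc2cnc(=O)n(CC(=O)OCC)c2)c(=O)nc1SCc1ccc(F)cc1`: 15%

All three compounds were tested in a functional assay on a cell-free system (plasma, Oryctolagus cuniculus) for inhibition of platelet-activating factor acetylhydrolase (Homo sapiens), tested at 100 nM; on this read-out lower numbers stand for less inhibition and higher numbers for more inhibition at the one concentration tested (going by the name of the read-out). Compound 3 gives the numerically largest of the three readings, yet its gap to compound 1 and its gap to compound 2 both lie within the usual scatter, so the three compounds cannot be told apart on these numbers. Among the compounds with values here, the only measured step between close relatives, a number 6 percentage points lower from compound 1 to compound 2 (within the scatter), is likewise within the scatter.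

Compound 4, `CCCCCCCCCCCCN(C)C(=O)Cn1cc(Cc2cnc(=O)n(CC(=O)NCCO)c2)c(=O)nc1SCc1ccc(F)cc1`, has not been measured. It differs from compound 3 in one place: (2-hydroxyethyl)amino in place of ethoxy on a carbonyl carbon. Within the data shown here, no measured pair shows this kind of change, so nothing among the known steps bears directly on it; the single known step is small, and every value so far sits low. The expectation for compound 4 is therefore a step of a number 3 percentage points lower from compound 3 to compound 4 (within the scatter), that is, no change beyond the scatter. Compound 4 is estimated at 12%, between 0% and 30% in this assay.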

Compound 4, a percentage reported as inhibition, at one concentration (the size of the read-out at that concentration, not a potency): 37%
The estimate for compound 4 lay 25 percentage points below the measured number; measured number outside the range, above it.
By their numbers in this assay, from the lowest: compounds 2, 1 and 3 (each within the scatter of the next); then compound 4.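

In this assay, putting (2-hydroxyethyl)amino in place of ethoxy on the carbonyl carbon gives a number 22 percentage points higher from compound 3 to compound 4 (beyond the scatter), the only step shown that lies beyond the scatter. This shows that the read-out can respond to what sits on this carbonyl carbon, turning an ester into an amide and bringing in 2 hydrogen-bond donors where ethoxy has 0, though the reading remains the size of an effect at one concentration, not a potency. Nothing available explains why the number rises.

The change alters two things at once, the amide link and the hydroxyl, and these compounds do not separate them: ethylamino on the same carbonyl carbon would keep the amide without the hydroxyl. As far as these compounds go, how a carboxylic acid or 2-methoxyethylamino would read there also stays open.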